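Cyano in place of isopropoxy: an expected step

This account rests on a few compounds, and the source may have more. Where it says the series, first, only, none or still open, it means among the compounds named here.

Compound 1 (`COc1ccc2c(c1)/C(=C/c1cc3c([nH]1)CCN(C(=O)N1CCN(C)CC1)C3)C(=O)N2`) gives 9 nM in an assay on isolated protein for inhibition of Leucine-rich repeat serine/threonine-protein kinase 2 (Homo sapiens), read by fluorescence, with a stated time of 60 min; on this read-out higher numbers stand for weaker inhibition and lower numbers for stronger inhibition.
Compound 2 (`CC(=O)N1CCc2[nH]c(/C=C3\C(=O)Nc4ccc(OC(C)C)cc43)cc2C1`) gives 4 nM in this assay.

Of the two numbers, compound 2 holds the lower one, and compound 1 stands above it by a margin beyond the usual scatter. Compound 3 (`CC(=O)N1CCc2[nH]c(/C=C3\C(=O)Nc4ccc(C#N)cc43)cc2C1`) differs from compound 2 by cyano in place of isopropoxy on an aromatic carbon. Within the data shown here, no measured pair shows this change, so nothing anchors its size. Compound 3 is expected to come out somewhat weaker, a modest step of a 2.0-fold higher number from compound 2 to compound 3 (0.30 log units; within the scatter) that may not clear the scatter. The estimate for compound 3 is 8 nM, within a range from 2 nM to 30 nM.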

Compound 3, half-maximal inhibitory concentration: 7 nM
Compound 3: the middle estimate sits 1.1-fold (0.06 log units) above what was measured, and the stated range covers the measured number.
By their numbers in this assay, from the lowest: compounds 2, 3 and 1 (each within the scatter of the next, the first and the last beyond it).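

At this aromatic carbon, cyano in place of isopropoxy gives a 1.8-fold higher number from compound 2 to compound 3 (0.24 log units; within the scatter) in this assay. Among these compounds, this is the first step read at this position, and it shows that the two groups, on an otherwise unchanged molecule, cannot be told apart in this read-out. The compounds shown leave open whether an amine or a carboxylic acid on this carbon would also leave the number within the scatter, or would move it beyond. No measurement offered here explains why the two groups read alike.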